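The source may hold more compounds than are shown below. What is called first, only, known or untested is meant among the compounds shown, and "the series" means these compounds.

In an ADME assay on L02 cells (Homo sapiens) for cytotoxicity, read by MTT assay, with a stated time of 24 h (a lower number here means a stronger inhibitor, a higher number a weaker inhibitor), compound 3 (`Cc1ccc(S(=O)(=O)N2C/C(=C\c3ccncc3)C(=O)/C(=C/c3ccccc3C(F)(F)F)C2)cc1`) gives 12800 nM, within the scatter of the other two measured compounds: compound 2 (`O=C1/C(=C/c2ccncc2)CNC/C1=C\c1ccccc1C(F)(F)F`) at 13400 nM and compound 1 (`O=C1/C(=C/c2cccnc2)CN(S(=O)(=O)c2ccc(Cl)cc2)C/C1=C\c1ccccc1C(F)(F)F`) at 11900 nM. Compound 4 (`O=C1/C(=C/c2ccncc2)CN(S(=O)(=O)c2ccc(Cl)cc2)C/C1=C\c1ccccc1C(F)(F)F`) differs from compound 3 by one change, (chloro in place of methyl on an aromatic carbon), which turns 4-methylphenyl into 4-chlorophenyl. Among the compounds with values here, the one measured step that bears on it, a 1.0-fold lower number from compound 2 to compound 3 (0.02 log units; within the scatter), introduced the whole (4-methylphenyl)sulfonyl group and stayed within the scatter. Compound 1 also carries (4-chlorophenyl)sulfonyl, and its value of 11900 nM lies within the scatter of compound 3, although it differs from compound 4 elsewhere. An estimated step of a 1.1-fold lower number from compound 3 to compound 4 (0.03 log units; within the scatter) is therefore expected, none beyond the scatter. For compound 4 the estimated value is 12000 nM, with an expected range of 7000 nM to 20000 nM.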

Compound 4, half-maximal inhibitory concentration: 14900 nM
Beside the measured number, compound 4's estimate is 1.2-fold (0.09 log units) below it; the measured number falls inside the stated range.
By their numbers in this assay, from the lowest: compounds 1, 3, 2 and 4 (each within the scatter of the next).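

In this assay, within the data shown here, chloro in place of methyl on an aromatic carbon, para to a large group, gives the first direct reading at this position (a 1.2-fold higher number from compound 3 to compound 4 (0.07 log units; within the scatter)). The whole (4-chlorophenyl)sulfonyl group in place of hydrogen on the ring amine nitrogen (a 1.1-fold higher number from compound 2 to compound 4 (0.05 log units; within the scatter)) and pyridin-4-yl in place of pyridin-3-yl (a 1.3-fold higher number from compound 1 to compound 4 (0.10 log units; within the scatter)) also leave the number within the scatter. No measurement shown accounts for these small steps. Going by these compounds, whether methoxy or a carboxylic acid on that aromatic carbon would move the number beyond the scatter remains open.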